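Chain Extension and Cytotoxicity in a Quinazoline Ester Series

A few compounds are considered here, and "the series" means these few. Any claim that something is new, unique, unknown or untested is made for them only; others in the source may bear on it.

Three compounds sharing one core were measured in a functional assay on A549 cells (Homo sapiens) for cytotoxicity, read by MTT assay, with a stated time of 24 h, tested at 60 uM; on this read-out lower numbers stand for a stronger effect and higher numbers for a weaker effect at the one concentration tested. Compound 1 `CCCCCCCCCOC(=O)CCC(=O)N1CCN(CCCOc2cc3c(Nc4ccc(F)c(Cl)c4)ncnc3cc2OC)CC1` gives 10.3% in this assay. Compound 2 `CCCCCCCCCCCCCCOC(=O)CCC(=O)N1CCN(CCCOc2cc3c(Nc4ccc(F)c(Cl)c4)ncnc3cc2OC)CC1` gives 84.9%, and compound 3 `CCCCCCCCCCCCCCCCCOC(=O)CCC(=O)N1CCN(CCCOc2cc3c(Nc4ccc(F)c(Cl)c4)ncnc3cc2OC)CC1` gives 84.1%. Compound 3 thus stands second highest of the three numbers; its nearest neighbour is compound 2, and the two differ only within the scatter, while compound 1 lies far below it. The steps of a number 74.6 percentage points higher from compound 1 to compound 2 (beyond the scatter) and a number 73.8 percentage points higher from compound 1 to compound 3 (beyond the scatter) were both large, whereas the step of a number 0.8 percentage points lower from compound 2 to compound 3 (within the scatter) stayed within the scatter.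

Compound 4 `CCCCCCCCCCCCCCCCCCCOC(=O)CCC(=O)N1CCN(CCCOc2cc3c(Nc4ccc(F)c(Cl)c4)ncnc3cc2OC)CC1` has not yet been measured. It differs from compound 3 by ethyl in place of hydrogen on a saturated chain carbon, ten or more bonds along the chain from an oxygen next to a carbonyl group. The step that bears most directly on this change is a number 0.8 percentage points lower from compound 2 to compound 3 (within the scatter), which was of the same kind and produced no movement beyond the scatter. The chain extension from compound 3 to compound 4 is therefore expected to give a number 0.1 percentage points lower from compound 3 to compound 4 (within the scatter), that is, no step beyond the scatter. Compound 4 is estimated to give 84% in this assay, within a range of 70% to 96%.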

Compound 4, a percentage reported as activity, at one concentration (the size of the read-out at that concentration, not a potency): 89.3%
Compound 4: the middle estimate sits 5.3 percentage points below what was measured; the range from low to high includes it.
By their numbers in this assay, from the lowest: compound 1; then compounds 3, 2 and 4 (each within the scatter of the next).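

Lengthening the chain further at this position still moved nothing in this assay: ethyl in place of hydrogen gave a number 5.2 percentage points higher from compound 3 to compound 4 (within the scatter), and pentyl in place of hydrogen gave a number 4.4 percentage points higher from compound 2 to compound 4 (within the scatter). The flat stretch therefore now spans three compounds, compound 2, compound 3 and compound 4, while the decyl change gave a number 79 percentage points higher from compound 1 to compound 4 (beyond the scatter), so among the compounds shown the whole large difference separates compound 1 from the other three. Nothing available here explains this flat stretch or the large difference.

Still open, going by these compounds, is where between the chains of compound 1 and compound 2 the large rise sets in. Also open, on these data alone, is how a shorter chain, or an amine or carboxylic acid at the chain end, would read in this assay.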